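A few compounds are considered here, and "the series" means these few. Any claim that something is new, unique, unknown or untested is made for them only; others in the source may bear on it.

Compound 1 `CC(=O)c1cc(-c2ccccc2)cc2cc(-c3ccc(F)cc3)[nH]c12`, 96.8%; compound 2 `COc1ccc(-c2cc3cc(-c4ccccc4)cc(C(C)=O)c3[nH]2)cc1`, 78.1%.

In a functional assay on MCF7 cells (Homo sapiens) for cytotoxicity, read by MTT assay, with a stated time of 2 days, tested at 1 uM (on this read-out lower numbers stand for a stronger effect and higher numbers for a weaker effect at the one concentration tested), compound 1 stands highest of the two numbers shown; its nearest neighbour is compound 2, reached by the step of a number 18.7 percentage points lower from compound 1 to compound 2 (beyond the scatter). Compound 3 `CC(=O)c1cc(/C=C/c2ccccc2)cc2cc(-c3ccc(F)cc3)[nH]c12` differs from compound 1 by 2-phenylethenyl in place of phenyl on an aromatic carbon. Among the measured compounds shown here, the one measured step alters a different part of the shared core, so no measured step bears on this change, and its size cannot be read from the data. The step of a number 6.8 percentage points lower from compound 1 to compound 3 (within the scatter) is therefore expected to lie within the scatter. Compound 3 is estimated at 90%, with a range from 70% to 105%.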

Compound 3, a percentage reported as activity, at one concentration (the size of the read-out at that concentration, not a potency): 86.9%
Estimate against measurement, compound 3: 3.1 percentage points above; the measured number falls inside the stated range.
By their numbers in this assay, from the lowest: compounds 2, 3 and 1 (each within the scatter of the next, the first and the last beyond it).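

In this assay, putting 2-phenylethenyl in place of phenyl on this aromatic carbon, meta to an acetyl group, gives a number 9.9 percentage points lower from compound 1 to compound 3 (within the scatter), so the read-out does not separate these two groups here. The earlier step, methoxy in place of fluoro, concerned a different place and said nothing about this one. No available evidence explains this result.

On these data alone, whether an amine or a carboxylic acid on this carbon would shift the number beyond the scatter remains open. As far as these compounds go, it is also open whether a longer chain carrying the phenyl ring would do so.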